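Working notes: acyl side chain, compound 3 to compound 4

The source may hold more compounds than are shown below. What is called first, only, known or untested is meant among the compounds shown, and "the series" means these compounds.

Measured in a functional assay on HeLa cells (Homo sapiens) for cytotoxicity, read by MTT assay; a lower number here means a stronger inhibitor, a higher number a weaker inhibitor:
- compound 1 `CC(C)=CC[C@@H](OC(=O)CCO)C1=CC(=O)c2c(O)ccc(O)c2C1=O`: 67600 nM
- compound 2 `CCCCC(O)CC(=O)O[C@H](CC=C(C)C)C1=CC(=O)c2c(O)ccc(O)c2C1=O`: 72200 nM
- compound 3 `CC(C)=CC[C@@H](OC(=O)CC(C)(O)C(C)C)C1=CC(=O)c2c(O)ccc(O)c2C1=O`: 27700 nM

Compound 3 holds the lowest number of the three. The next structure is compound 4 `CC(=O)OC(C)CO[C@H](CC=C(C)C)C1=CC(=O)c2c(O)ccc(O)c2C1=O`, with the change (2-acetoxypropyl in place of (2-hydroxy-2,3-dimethylbutyl)carbonyl on an oxygen on a saturated carbon). In words, 2-acetoxypropyl stands in place of (2-hydroxy-2,3-dimethylbutyl)carbonyl on an oxygen on a saturated carbon.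

The nearest evidence is modest: a 2.4-fold lower number from compound 1 to compound 3 (0.39 log units; beyond the scatter) and a 2.6-fold lower number from compound 2 to compound 3 (0.42 log units; beyond the scatter). By contrast, a 1.1-fold higher number from compound 1 to compound 2 (0.03 log units; within the scatter) stays within the scatter. Going by the values given here, no measured step removes the carbonyl on that oxygen, so the evidence is indirect. A modest step to a higher number is expected in this assay, back toward compound 1 and compound 2.

The expected step is a 1.7-fold higher number from compound 3 to compound 4 (0.24 log units; within the scatter).

The estimate for compound 4 is 48000 nM, with an expected range of 20000 nM to 100000 nM.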

Compound 4, half-maximal inhibitory concentration: 40100 nM
Beside the measured number, compound 4's estimate is 1.2-fold (0.08 log units) above it; the measured number falls inside the stated range.
By their numbers in this assay, from the lowest: compounds 3, 4, 1 and 2 (each within the scatter of the next, the first and the last beyond it).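

In this assay, 2-acetoxypropyl in place of (2-hydroxy-2,3-dimethylbutyl)carbonyl on this oxygen stays within the scatter (a 1.4-fold higher number from compound 3 to compound 4 (0.16 log units; within the scatter)), as do the comparisons with the other two side chains (a 1.8-fold lower number from compound 2 to compound 4 (0.26 log units; within the scatter)) and (a 1.7-fold lower number from compound 1 to compound 4 (0.23 log units; within the scatter)). The carbonyl directly on this oxygen and the side-chain hydroxyl are therefore both absent in compound 4, yet its number lies within the scatter of all three earlier compounds. Nothing available explains this result.

As far as these compounds go, whether an amine or a carboxylic acid on this side chain would shift the number beyond the scatter remains open. From the compounds shown here alone, the effect of a longer chain carrying the acetoxy group also remains open.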